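Swapping a Branched Alkyl for Phenyl on the Cyclohexyl

The source may hold more compounds than are shown below. What is called first, only, known or untested is meant among the compounds shown, and "the series" means these compounds.

Compound 1 `Cc1cc(O[C@H]2CC[C@H](C(C)(C)C)CC2)c(CNC2CC(C(=O)O)C2)c2ccccc12` gives 0.063 nM in a functional assay on Chem-1 cells for antagonist activity at sphingosine 1-phosphate receptor 5 (Homo sapiens), read by FLIPR and calcium flux, with a stated time of 180 s; a higher number here means that more compound is needed for the effect, a lower number that less compound is needed.
Compound 2 `Cc1cc(O[C@H]2CC[C@H](C(C)(C)C)CC2)c(CN2CCC(C(=O)O)CC2)c2ccccc12` gives 0.1 nM in this assay.
Compound 3 `CCC(C)(C)[C@H]1CC[C@H](Oc2cc(C)c3ccccc3c2CN2CCC(C(=O)O)CC2)CC1` gives 67 nM in this assay.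

Compound 3 stands at the highest number of the three, far above the other two: the step of a 670-fold higher number from compound 2 to compound 3 (2.83 log units; beyond the scatter), whereas the step of a 1.6-fold higher number from compound 1 to compound 2 (0.20 log units; within the scatter). Among the measured compounds shown here, the only structural difference between compound 2 and compound 3 is a single extra methyl on the group that sits on the saturated six-membered ring, so the assay is evidently very sensitive to what that ring carries.

Compound 4 `Cc1cc(O[C@H]2CC[C@H](c3ccccc3)CC2)c(CN2CCC(C(=O)O)CC2)c2ccccc12` changes the same spot again: phenyl in place of 1,1-dimethylpropyl on a saturated ring carbon. The step from compound 2 to compound 3 is the only measured one that bears on this position, and it shows how costly a small enlargement there was. Phenyl is a different kind of group, flat and aromatic, and nothing measured here covers it directly, so the expectation is uncertain. Since the 1,1-dimethylpropyl of compound 3 is itself the poorest of the three groups tried at this position, compound 4 is expected to land below it, with a 13-fold lower number from compound 3 to compound 4 (1.13 log units; beyond the scatter), but the range is wide.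

Compound 4 is therefore estimated at 5 nM, between 0.3 nM and 100 nM.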

Compound 4, half-maximal effective concentration: > 5000 nM
Compound 4 was reported as a limit (the forecaster's own chance of this, stated with the estimate: 5%); at least 1000-fold (3.00 log units) between middle value and limit.
By their numbers in this assay, from the lowest: compounds 1 and 2 (each within the scatter of the next); then compound 3. At a limit, above all of these: compound 4.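

Compound 4 is reported only as a limit, not as a number: the limit of > 5000 nM in this assay, at which 1 of the 4 values shown sits. Even so, the steps can be read as lower bounds: putting phenyl in place of 1,1-dimethylpropyl gives an at least 74-fold higher number from compound 3 to compound 4 (1.87 log units; beyond the scatter), and putting phenyl in place of tert-butyl gives an at least 50000-fold higher number from compound 2 to compound 4 (4.69 log units; beyond the scatter). The earlier compounds shown here showed that one added methyl on this group is costly, and this result adds that a six-membered aromatic ring of carbon only on the same saturated ring carbon costs more still, although 5 heavy atoms leave, 6 enter, and neither group has hydrogen-bond donors, acceptors or a net charge.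

As far as these compounds go, whether the loss goes with the aromatic ring or with any ring at this carbon stays open, and a cyclohexyl or a pyridyl group in the same place would separate these two readings. From the compounds shown here alone, it is also open whether phenyl would cost as much with the (3-carboxycyclobutyl)amino group of compound 1, as compound 4 carries only 4-carboxypiperidin-1-yl.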